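This account rests on a few compounds, and the source may have more. Where it says the series, first, only, none or still open, it means among the compounds named here.

Of the compounds shown here, two of the shared core have been measured. Compound 1 `Cc1cc(O)cc(-c2nn(CC#N)cc2-c2ccnc(-c3ccc(Oc4ccccc4)cc3)c2)c1` carries a phenoxyphenyl group and a hydroxy, and in a functional assay on OVCAR-8 cells (Homo sapiens) for inhibition, read by sulforhodamine B assay, with a stated time of 48 h (on this read-out higher numbers stand for weaker inhibition of growth and lower numbers for stronger inhibition of growth), compound 1 gives 2080 nM. Compound 2 `COc1cc(C)cc(-c2nn(CC#N)cc2-c2ccnc(-c3ccc(N(C)C)cc3)c2)c1` carries a dimethylaminophenyl group and a methoxy, and in this assay compound 2 gives 522 nM, the lower of the two numbers; the gap from compound 1 to compound 2 lies beyond the usual scatter. Since these two compounds differ in two places, the two values alone do not show how much of that gap belongs to either change.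

Compound 3 `Cc1cc(O)cc(-c2nn(CC#N)cc2-c2ccnc(-c3ccc(N(C)C)cc3)c2)c1` is still unmeasured. It differs from compound 2 by hydrogen in place of methyl on an oxygen on an aromatic ring. For the measured compounds named here, no pair of measured compounds isolates this change, so the direction of the step is open. Compound 3 is expected to give 750 nM in this assay, within a range of 250 nM to 2200 nM. The step of a 1.4-fold higher number from compound 2 to compound 3 (0.16 log units; within the scatter) that this estimate means is expected to stay close to the scatter, with the wider range reflecting that the hydroxy analogue compound 1 gave 2080 nM with a different second group.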

Compound 3, concentration for 50% growth inhibition: 4200 nM
For compound 3 the middle estimate is 5.6-fold (0.75 log units) below the measured one; measured number outside the range, above it.
By their numbers in this assay, from the lowest: compound 2; then compound 1; then compound 3.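

For the compounds shown here, with the dimethylaminophenyl group held constant, the change from 3-methoxy-5-methylphenyl to 3-hydroxy-5-methylphenyl gives an 8.0-fold higher number from compound 2 to compound 3 (0.91 log units; beyond the scatter) in this assay and is the first single change read at this site, showing that the methyl on the oxygen counts for much in growth inhibition. With the hydroxy held constant, dimethylamino in place of phenoxy gives a 2.0-fold higher number from compound 1 to compound 3 (0.31 log units; beyond the scatter) and only just clears the usual scatter, so the lower number of compound 2 cannot be credited to its dimethylaminophenyl group, and the larger single step belongs to the methoxy-to-hydroxy change. No measurement on hand explains why removing this methyl weakens growth inhibition so clearly.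

The compounds shown leave open whether methoxy would bring a similar gain alongside the phenoxyphenyl group, since the methoxy step has been read only with dimethylamino present. They also leave open whether an ethoxy group, or a longer chain on the same oxygen, would match methoxy or whether the effect is confined to the methyl itself.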